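This account rests on a few compounds, and the source may have more. Where it says the series, first, only, none or still open, it means among the compounds named here.

Compound 2 `COc1ccc(NC(=O)Nc2cc(C)nc3ccccc23)cc1F` is measured in a physicochemical assay for solubility, at pH 7.4 (on this read-out higher numbers stand for higher solubility and lower numbers for lower solubility), where compound 2 gives 2700 nM. Going by the values given here, of the three numbers so far, this is the smallest: compound 3 `Cc1cc(NC(=O)Nc2ccccc2C(F)(F)F)c2ccccc2n1` gives 3800 nM, a number within the usual scatter of that of compound 2, while compound 1 `COc1ccc(NC(=O)Nc2cc(C)nc3ccccc23)cc1` gives 19800 nM, well beyond it. Compound 4 `Cc1cc(NC(=O)Nc2ccc(F)c(F)c2)c2ccccc2n1` differs from compound 2 by fluoro in place of methoxy on an aromatic carbon. Among the compounds with values here, one measured step bears on this: a 7.3-fold lower number from compound 1 to compound 2 (0.87 log units; beyond the scatter). Within the data shown here, that step puts a fluoro group in for hydrogen rather than for methoxy, so it speaks to the change only loosely, and no measured step here covers the loss of a methoxy group. A small further drop, or no step beyond the scatter, is expected. Compound 4 is therefore estimated at 1800 nM, between 600 nM and 5400 nM, which would mean a 1.5-fold lower number from compound 2 to compound 4 (0.18 log units; within the scatter).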

Compound 4, solubility: 500 nM
Compound 4: the middle estimate sits 3.6-fold (0.56 log units) above what was measured; measured number below the stated range.
By their numbers in this assay, from the lowest: compound 4; then compounds 2 and 3 (each within the scatter of the next); then compound 1.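

In this assay, fluoro in place of methoxy, on the carbon ortho to a fluoro group and para to a large group, gives a 5.4-fold lower number from compound 2 to compound 4 (0.73 log units; beyond the scatter) and places compound 4 lowest of the four. Going by these compounds alone, the earlier step on this ring only put fluoro in for hydrogen, so this is the first sign that replacing the methoxy group also moves the number, and in the same downward direction. Nothing measured here explains this drop.

The compounds shown leave open how a hydroxyl group, an amine or a carboxylic acid on this carbon would compare with methoxy and fluoro. They also leave open whether the drop would persist without the other fluoro group on the ring.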